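Furan for Thiophene on a Diaryl Amine Scaffold

The compounds below may be only part of what the source reports. "The series", "measured", "known", "first", "only" and "open" are said of these compounds alone.

Compound 1 `CCN(c1ccc(C#N)c(Cl)c1)c1cc(-c2cccs2)ccc1C` — a functional assay on VCaP cells (Homo sapiens) for antiproliferative activity, read by CCK-8 assay, with a stated time of 6 days; a higher number here means a weaker inhibitor, a lower number a stronger inhibitor: "not determined" (no result reported)
Compound 2 `N#Cc1ccc(N2CCCc3c(-c4ccncc4)cccc32)cc1C(F)(F)F` — this assay: > 30000 nM

Going by the values given here, only two compounds have been put through this assay. For compound 1 no result is reported, so it stands nowhere on the numbers yet. Compound 2 gives only a limit in this assay, > 30000 nM, and not a number. Among the compounds with values here, the one value shown is therefore (the limit of > 30000 nM in this assay, at which 1 of the 2 values shown sits), and compound 2 shares no structural change with compound 1 that could be counted as a step, so nothing is said here about what separates the two.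

Compound 3 `CCN(c1ccc(C#N)c(Cl)c1)c1cc(-c2ccco2)ccc1C` is not yet measured. It differs from compound 1 in one place: furan-2-yl in place of thiophen-2-yl on an aromatic carbon. Within the data shown here, no step between measured compounds gives the size of such an exchange, so for this assay no shift beyond the usual scatter is expected in either direction; the value for compound 3 is expected to sit close to wherever compound 1 would fall.

With compound 1 itself unmeasured, the estimate for compound 3 is expected near 5000 nM, within a range from 500 nM to 30000 nM.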

Compound 3, half-maximal inhibitory concentration: > 30000 nM
Compound 3 gave a limit, no number; the forecaster's own chance of this, stated with the estimate: 35%; middle value at least 6.0-fold (0.77 log units) away from the limit.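

In this assay compound 3 gives > 30000 nM, which is a limit and not a number. Going by these compounds alone, for compound 1 the entry reads "not determined" (no result reported), so no step between compound 1 and compound 3 can be read. The compounds shown leave open whether exchanging thiophen-2-yl for furan-2-yl on this scaffold changes antiproliferative potency at all.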